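Chloro or methyl on the aromatic ring, and a pyridine swap

A few compounds are considered here, and "the series" means these few. Any claim that something is new, unique, unknown or untested is made for them only; others in the source may bear on it.

Measured in a functional assay on RBL-2H3 cells (Rattus norvegicus) for inhibition, with stated times of 30 min and 1 h; on this read-out lower numbers stand for stronger inhibition and higher numbers for weaker inhibition:
- compound 1 `COc1ccc(CN(CCN(C)C)c2ccccc2)cc1`: 243 nM
- compound 2 `COc1ccc(CN(CCN(C)C)c2ccc(Cl)cc2)cc1`: 40.2 nM
- compound 3 `COc1ccc(CN(CCN(C)C)c2ccc(C)cc2)cc1`: 89.1 nM

Compound 3 sits in the middle of these three numbers, higher than compound 2 and lower than compound 1. Compound 4 `COc1ccc(CN(CCN(C)C)c2ccc(Cl)cn2)cc1` differs from it as follows: 5-chloropyridin-2-yl in place of 4-methylphenyl on an amine nitrogen. Among the compounds with values here, three measured steps bear on this change: a 6.0-fold lower number from compound 1 to compound 2 (0.78 log units; beyond the scatter), a 2.7-fold lower number from compound 1 to compound 3 (0.44 log units; beyond the scatter) and a 2.2-fold higher number from compound 2 to compound 3 (0.35 log units; beyond the scatter). All are modest, and they favour chloro over methyl. Within the data shown here, no measured compound has a hetero atom in that aromatic ring, so that part remains unknown and the range is wide. In this assay, a modest step to a lower number is expected, and the expected step is a 2.0-fold lower number from compound 3 to compound 4 (0.30 log units; within the scatter). For compound 4 the estimate is 45 nM, with an expected range of 11 nM to 180 nM.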

Compound 4, half-maximal inhibitory concentration: 19.2 nM
The estimate for compound 4 lay 2.3-fold (0.37 log units) above the measured number, within the range that was stated.
By their numbers in this assay, from the lowest: compound 4; then compound 2; then compound 3; then compound 1.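

In this assay the aromatic ring on the amine nitrogen accepts a ring nitrogen, and with chloro on both rings, 5-chloropyridin-2-yl in place of 4-chlorophenyl gives a 2.1-fold lower number from compound 2 to compound 4 (0.32 log units; beyond the scatter) as a further gain. Against 4-methylphenyl the same ring gives a 4.6-fold lower number from compound 3 to compound 4 (0.67 log units; beyond the scatter) in this comparison. Against plain phenyl it gives a 13-fold lower number from compound 1 to compound 4 (1.10 log units; beyond the scatter) as the only large step in the set.

No measurement shown here accounts for this gain.
As far as these compounds go, whether the ring nitrogen helps without chloro, as in unsubstituted pyridin-2-yl or 5-methylpyridin-2-yl, remains open.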